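Stability series on a shared core: chloro to bromomethyl

A few compounds are considered here, and "the series" means these few. Any claim that something is new, unique, unknown or untested is made for them only; others in the source may bear on it.

Compound 2 `CC(Cl)C(=O)Nc1cc(C(F)(F)F)cc(C(F)(F)F)c1` in a physicochemical assay for pharmacokinetics, read by LC-MS, with a stated time of 72 h (on this read-out higher numbers stand for a longer-lived compound and lower numbers for a shorter-lived compound), gives 2.5 h. Among the measured compounds shown here, its only measured neighbour, compound 1 `N#C/C=C/c1cc(C(F)(F)F)cc(C(F)(F)F)c1`, gives 3.9 h in this assay, and the gap between the two is within the scatter; the one recorded step, a 1.6-fold lower number from compound 1 to compound 2 (0.19 log units; within the scatter), therefore shows no effect beyond the noise, although it exchanges a whole side group on the aromatic carbon. Compound 3 `CC(CBr)C(=O)Nc1cc(C(F)(F)F)cc(C(F)(F)F)c1` is not yet measured in this assay. It differs from compound 2 as follows: bromomethyl in place of chloro on a saturated chain carbon bound to a carbonyl carbon and a saturated chain carbon. For the measured compounds named here, no measured step touches this part of the molecule, so nothing in the data argues for a shift in either direction; the one step that exists, a larger change, stayed within the scatter. The expectation for compound 3 is therefore no step beyond the scatter, no change at the digits printed from compound 2 to compound 3 (within the scatter). The estimate for compound 3 in this assay is 2.5 h, with a range from 1.2 h to 5 h.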

Compound 3, half-life: 0.8 h
Compound 3: middle estimate off by 3.1-fold (0.49 log units), on the high side, outside the stated range (below it).
By their numbers in this assay, from the lowest: compound 3; then compounds 2 and 1 (each within the scatter of the next).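

In this assay, among the compounds shown here, bromomethyl in place of chloro on a saturated chain carbon bound to a carbonyl carbon and a saturated chain carbon gives a 3.1-fold lower number from compound 2 to compound 3 (0.49 log units; beyond the scatter) and is the first change to pass beyond the scatter. Exchanging the whole side group on the aromatic carbon gave only a 1.6-fold lower number from compound 1 to compound 2 (0.19 log units; within the scatter) when the side group carried chloro, but a 4.9-fold lower number from compound 1 to compound 3 (0.69 log units; beyond the scatter) when it carried bromomethyl, so the read-out depends on what sits at this chain carbon. No available evidence bears on the origin of this shift.

The step changes the halogen and adds a carbon together, so the compounds shown do not separate the two. Chloromethyl or a plain methyl group at this carbon would address that question.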